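The source may report more compounds than this note shows. Statements on the series, on what has been measured and on what is new or still open speak of the compounds shown alone.

Compound 1 `S=c1[nH]nc(Cc2ccc(Cl)cc2Oc2ccccc2Cl)[nH]1` gives 159% in a functional assay on the whole organism (strain NMRI) with Mus musculus as the target, with a stated time of 60 min, at a dose of 20 mg/kg by the intraperitoneal route; on this read-out lower numbers stand for a weaker effect and higher numbers for a stronger effect at the one dose given; compound 2 `CCSc1nnc(Cc2ccc(Cl)cc2Oc2ccccc2Cl)[nH]1` gives 174%; compound 3 `CCSc1nnc(Cc2ccc(Cl)cc2Oc2ccccc2F)[nH]1` gives 141%.

Compound 3 holds the lowest of the three numbers in this assay: compound 1 lies above it beyond the scatter, and the step of a number 33 percentage points lower from compound 2 to compound 3 (beyond the scatter) separates it from compound 2. Compound 4 `CCOc1nnc(Cc2ccc(Cl)cc2Oc2ccccc2F)[nH]1` differs from compound 3 by ethoxy in place of ethylsulfanyl on an aromatic carbon. Within the data shown here, no measured step exchanges ethoxy for ethylsulfanyl. Only a number 15 percentage points higher from compound 1 to compound 2 (beyond the scatter) concerns the group on the five-membered aromatic ring, and that step was modest; a number 33 percentage points lower from compound 2 to compound 3 (beyond the scatter) was large but concerns fluoro in place of chloro. The expected step of a number 6 percentage points lower from compound 3 to compound 4 (within the scatter) is therefore small, with its direction uncertain. Compound 4 is estimated at 135%, within a range from 100% to 170%.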

Compound 4, a percentage reported as activity, at one dose (the size of the read-out at that dose, not a potency): 138%
Compound 4: middle estimate off by 3 percentage points, on the low side, and the stated range covers the measured number.
By their numbers in this assay, from the lowest: compounds 4 and 3 (each within the scatter of the next); then compound 1; then compound 2.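

The step of a number 3 percentage points lower from compound 3 to compound 4 (within the scatter) in this assay shows that, on this aromatic carbon between two ring nitrogen atoms, ethoxy in place of ethylsulfanyl leaves the read-out within the scatter. The earlier step at this ring involved a different group, whereas here the exchange keeps the heavy-atom count and swaps only sulfur for oxygen. Nothing available explains this result.

As far as these compounds go, it remains open whether ethoxy would match ethylsulfanyl in the chloro series of compound 2. From the compounds shown here alone, how an amine or a longer chain would behave on this carbon is also open.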